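The compounds below may be only part of what the source reports. "The series", "measured", "known", "first", "only" and "open" are said of these compounds alone.

Series notes. Compound 1 `NC1=NC2(CCSCC2)N(OCCCOc2ccccc2Br)C(N)=N1` in a functional assay on HepG2 cells (Homo sapiens) for antiproliferative activity, read by MTT assay, with a stated time of 72 h (a lower number here means a stronger inhibitor, a higher number a weaker inhibitor), gives 90 nM. Compound 3 `NC1=NC2(CCSCC2)N(OCCCOc2ccccc2Cl)C(N)=N1` differs from it by chloro in place of bromo on an aromatic carbon; in this assay compound 3 gives 80 nM, and the step is a 1.1-fold lower number from compound 1 to compound 3 (0.05 log units; within the scatter). Compound 2 `NC1=NC2(CCOCC2)N(OCCCOc2cccc(Br)c2)C(N)=N1` carries a different core; the difference between the two cores is not broken down here. In this assay compound 2 gives 320 nM, the highest number of the three measured. Compound 4 `NC1=NC2(CCOCC2)N(OCCCOc2cccc(Cl)c2)C(N)=N1` differs from compound 2 by chloro in place of bromo on an aromatic carbon. This is the same kind of change as that between compound 1 and compound 3, but there the halogen sits ortho to a large group, whereas in compound 4 it sits meta to a large group. Resting on the small step of a 1.1-fold lower number from compound 1 to compound 3 (0.05 log units; within the scatter), the expected step is a 1.1-fold lower number from compound 2 to compound 4 (0.03 log units; within the scatter). For compound 4 in this assay the estimate is 300 nM, between 150 nM and 600 nM.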

Compound 4, half-maximal inhibitory concentration: 150 nM
Compound 4: the middle estimate sits 2.0-fold (0.30 log units) above what was measured; measured number inside the range.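

In this assay chloro in place of bromo on the aromatic carbon gives a 2.1-fold lower number from compound 2 to compound 4 (0.33 log units; beyond the scatter). Set beside the earlier step, the change carries across these two cores with no gap that stands out from the scatter: the same change on two cores in this assay, a 1.1-fold lower number (0.05 log units; within the scatter) from compound 1 to compound 3 and a 2.1-fold lower number (0.33 log units; beyond the scatter) from compound 2 to compound 4, 1.9-fold (0.28 log units) apart, within the scatter of two such steps. Among these compounds, this rests on only two pairs, which differ in the core and also in where the halogen sits on the ring, so it does not show that the step would hold on other cores or that either difference has no influence.

Open, as far as these compounds go, is how fluoro, methoxy or an amine on the same aromatic ring would compare with the two halogens. Also open, from the compounds shown here alone, is whether a longer linking chain would leave the step unchanged.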